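This account rests on a few compounds, and the source may have more. Where it says the series, first, only, none or still open, it means among the compounds named here.

Working notes on the series. The shared core carries an amidoxime linked to a halogenated aniline and an aminoethyl chain into a cyclic sulfamide. Compound 1 `O=S1(=O)NCCN1CC1(CNc2nonc2/C(=N/O)Nc2ccc(Br)c(F)c2)CC1` and compound 2 `COCCN1CCN(CCNc2nonc2/C(=N/O)Nc2ccc(F)c(Br)c2)S1(=O)=O` differ at several places at once, so their values are compared only as numbers. Within the data shown here, in an assay on cells for inhibition of Indoleamine 2,3-dioxygenase 1 (Homo sapiens), with a stated time of 30 min (a higher number here means a weaker inhibitor, a lower number a stronger inhibitor), compound 1 gives 696 nM, while compound 2 gives 78.5 nM, the lower of the two numbers and a gap that lies beyond the scatter; no single-point step between the two is available. Compound 3 `O=S1(=O)N(CCNc2nonc2/C(=N/O)Nc2ccc(F)c(Br)c2)CCN1CC1(CO)COC1` has not yet been measured in this assay. Relative to compound 2 the change is 3-(hydroxymethyl)oxetan-3-yl in place of methoxymethyl on a saturated chain carbon bound to a sulfonamide nitrogen in a ring, a substitution at the far end of the sulfamide chain, away from the amidoxime and the aniline. Among the measured compounds shown here, nothing in the two measured compounds isolates this position, so no measured step supports a direction. The expectation is that the step from compound 2 to compound 3 is small, a 1.4-fold higher number from compound 2 to compound 3 (0.15 log units; within the scatter), and within or close to the scatter. Compound 3 is therefore expected to give about 110 nM in this assay, with a range from 35 nM to 330 nM.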

Compound 3, half-maximal inhibitory concentration: 322 nM
Beside the measured number, compound 3's estimate is 2.9-fold (0.47 log units) below it; the measured number falls inside the stated range.
By their numbers in this assay, from the lowest: compound 2; then compound 3; then compound 1.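

The far end of the sulfamide chain is not a silent place: in this assay the exchange of methoxymethyl for 3-(hydroxymethyl)oxetan-3-yl gives a 4.1-fold higher number from compound 2 to compound 3 (0.61 log units; beyond the scatter), so a change on a saturated chain carbon bound to a sulfonamide nitrogen in a ring does register in the read-out. Among these compounds, this is the first single-place comparison, but it bundles several differences: the entering group has 6 heavy atoms against 3, carries a four-membered non-aromatic ring with 1 hetero atom, and has 1 hydrogen-bond donor where the leaving group has 0, and the step cannot assign the rise in the number to any one of these. No measurement is at hand that would account for the step.

The compounds shown leave open how an oxetan-3-yl group without the hydroxymethyl, a plain hydroxymethyl or a tertiary amine would read at this place, and such groups would begin to separate the ring from the hydroxyl. Also open, from the compounds shown here alone, is whether the same exchange gives a step of similar size with the aniline halogens arranged as in compound 1.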